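Removing the trifluoromethyl from the aryl piperazine

This account rests on a few compounds, and the source may have more. Where it says the series, first, only, none or still open, it means among the compounds named here.

Compound 2 `O=C(CCN1C(=O)CSc2ccccc21)NCCCN1CCN(c2ccc(C(F)(F)F)cc2)CC1`: 20400 nM
Compound 1 `COc1ccccc1N1CCN(CCCNC(=O)CCN2C(=O)CSc3ccccc32)CC1`: 2000 nM

Among the measured compounds shown here, in a functional assay on MDA-MB-231 cells (Homo sapiens) for inhibition, read by sulforhodamine B assay, with a stated time of 48 h (a higher number here means a weaker inhibitor of growth, a lower number a stronger inhibitor of growth), compound 2 stands highest of the two measured, with compound 1 its only neighbour, and the step of a 10-fold higher number from compound 1 to compound 2 (1.01 log units; beyond the scatter) is the sole comparison available. Compound 3 `O=C(CCN1C(=O)CSc2ccccc21)NCCCN1CCN(c2ccccc2)CC1` differs from compound 2 by hydrogen in place of trifluoromethyl on an aromatic carbon. Since exchanging the substituted phenyl of compound 1 for that of compound 2 raised the number by a large margin, stripping the trifluoromethyl is expected to move back toward compound 1, though how far is uncertain. Compound 3 is therefore estimated at 5000 nM (range 2000 nM to 15000 nM), an expected step of a 4.1-fold lower number from compound 2 to compound 3 (0.61 log units; beyond the scatter).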

Compound 3, concentration for 50% growth inhibition: < 10 nM
Compound 3: only a limit was reported; the forecaster's own chance of this, stated with the estimate: 5%; middle value at least 500-fold (2.69 log units) from the limit.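

In this assay, compound 3 is reported only as a limit, not a number: the limit of < 10 nM in this assay, at which 1 of the 3 values shown sits.

Replacing trifluoromethyl with hydrogen gives an at least 2000-fold lower number from compound 2 to compound 3 (3.30 log units; beyond the scatter), showing that this place on the phenyl ring, para to a large group, governs the read-out far more strongly than the earlier pair suggested. Hydrogen in place of methoxy gives an at least 200-fold lower number from compound 1 to compound 3 (2.30 log units; beyond the scatter), so the unsubstituted phenyl surpasses both substituted phenyls shown.

From the compounds shown here alone, how far past its limit compound 3 truly lies remains open. So does whether a fluorine or a methyl at that aromatic carbon would retain this strength of growth inhibition.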